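A few compounds are considered here, and "the series" means these few. Any claim that something is new, unique, unknown or untested is made for them only; others in the source may bear on it.

Measured so far in an in vitro functional assay on HEK285-7 cells for antagonist activity at prostaglandin D2 receptor 2 (Homo sapiens), read by BRET and beta-arrestin recruitment; a lower number here means a stronger inhibitor, a higher number a weaker inhibitor:
compound 1 `O=C(O)Cc1sc(C(c2ccc(F)cc2)c2ccc(F)cc2)nc1-c1ccnc(F)c1` gives 4.7 nM;
compound 2 `O=C(O)Cc1sc(C(c2ccccc2)c2ccc(Cl)cc2)nc1-c1ccc(Cl)cc1` gives 75 nM.

Of these two numbers, compound 1 stands lowest, and the gap from compound 1 to compound 2 is beyond the scatter. Compound 3 `O=C(O)Cc1sc(C(c2ccc(F)cc2)c2ccc(F)cc2)nc1-c1ccc(Cl)cc1` is not yet measured. It differs from compound 1 in one place: 4-chlorophenyl in place of 2-fluoropyridin-4-yl on an aromatic carbon. For the measured compounds named here, no measured step shows this change directly, and compound 2 differs from compound 3 in two places, so it gives only a loose bearing. A rise beyond the scatter in this assay is expected, but one smaller than the gap between compound 1 and compound 2. For compound 3 the expected value is 20 nM, range 6 nM to 70 nM, an expected step of a 4.3-fold higher number from compound 1 to compound 3 (0.63 log units; beyond the scatter).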

Compound 3, half-maximal inhibitory concentration: 180 nM
The estimate for compound 3 lay 9.0-fold (0.95 log units) below the measured number; the whole stated range lies below it.
By their numbers in this assay, from the lowest: compound 1; then compound 2; then compound 3.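

In this assay, the group on this aromatic carbon, next to the ring nitrogen, proves decisive: 4-chlorophenyl in place of 2-fluoropyridin-4-yl gives a 38-fold higher number from compound 1 to compound 3 (1.58 log units; beyond the scatter), with the rest of compound 1 unchanged. The two groups have the same number of heavy atoms, so the step comes with an exchange of atoms and the loss of a hydrogen-bond acceptor, not a change in that count. No measurement available here explains the size of this step.

On these data alone, whether the ring nitrogen or the halogen carries the step remains open. A 4-fluorophenyl or a pyridin-4-yl group at this position would separate the two.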